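From hydroxy to phenyl on the shared core

A few compounds are considered here, and "the series" means these few. Any claim that something is new, unique, unknown or untested is made for them only; others in the source may bear on it.

Compound 1 `Cc1nnc(-c2nn(-c3ccccc3)c(-c3ccccc3)c2C#N)c2cn(-c3ccccc3)nc12`: 8460 nM
Compound 2 `N#Cc1c(-c2nnc(O)c3nn(-c4ccccc4)cc23)nn(-c2ccccc2)c1-c1ccccc1`: > 100000 nM, a limit

In a functional assay on MCF7 cells (Homo sapiens) for inhibition, read by sulforhodamine B assay, with a stated time of 48 h (a lower number here means a stronger inhibitor of growth, a higher number a weaker inhibitor of growth), compound 2 stands at > 100000 nM, which is a limit of the assay and not a number. Compound 3 `N#Cc1c(-c2nnc(-c3ccccc3)c3nn(-c4ccccc4)cc23)nn(-c2ccccc2)c1-c1ccccc1` differs from it by one change, phenyl in place of hydroxy on an aromatic carbon. Among the measured compounds shown here, the only measured step bearing on this is an at least 11-fold higher number from compound 1 to compound 2 (1.07 log units; beyond the scatter), with hydroxy in place of methyl. A large step to a lower number is therefore expected in this assay, since compound 1, without the hydroxy, gives 8460 nM. The expected step is an at least 11-fold lower number from compound 2 to compound 3 (1.04 log units; beyond the scatter). The estimate for compound 3 is 9000 nM, with an expected range of 2500 nM to 40000 nM.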

Compound 3, concentration for 50% growth inhibition: 9530 nM
Estimate against measurement, compound 3: 1.1-fold (0.02 log units) below; the range from low to high includes it.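

At this position, on an aromatic carbon next to the ring nitrogen, this assay shows that phenyl in place of hydroxy gives an at least 10-fold lower number from compound 2 to compound 3 (1.02 log units; beyond the scatter). Phenyl and methyl are not told apart here, with a 1.1-fold higher number from compound 1 to compound 3 (0.05 log units; within the scatter), so a whole aromatic ring at this position gives the same reading as methyl. Of the three groups, only hydroxy stands apart, and the value of compound 2 is a limit of the assay and not a number: the limit of > 100000 nM in this assay, at which 1 of the 3 values shown sits.

As far as these compounds go, whether an amine or a methoxy group here would read like methyl and phenyl or like hydroxy remains open. So does whether a chlorophenyl group would differ from the phenyl of compound 3.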